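The compounds below may be only part of what the source reports. "The series", "measured", "known", "first", "only" and "open" are said of these compounds alone.

Four compounds share one core here: compound 1 (`CC(=O)NCc1ccc2c(c1)nc(Cn1c(=O)n(C(C)C)c3ccccc31)n2CCC(C)C`), compound 2 (`CC(C)CCn1c(Cn2c(=O)n(C(C)C)c3ccccc32)nc2cc(CO)ccc21`), compound 3 (`CC(C)CCn1c(Cn2c(=O)n(C(C)C)c3ccccc32)nc2ccc(CN)cc21`) and compound 4 (`COC(=O)c1ccc2c(c1)nc(Cn1c(=O)n(C(C)C)c3ccccc31)n2CCC(C)C`), which has not yet been measured. In an ADME assay on HEp-2 cells (Homo sapiens) for cytotoxicity (on this read-out higher numbers stand for lower toxicity in this test and lower numbers for higher toxicity in this test), compound 1 gives 178000 nM, compound 2 gives 31600 nM and compound 3 gives 28100 nM. Compound 2 therefore cannot be told apart from compound 3, and the numbers of both lie clearly under that of compound 1.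

The move to compound 4 puts methoxycarbonyl in place of hydroxymethyl on an aromatic carbon. For the measured compounds named here, only one measured step bears on this change: a 5.6-fold lower number from compound 1 to compound 2 (0.75 log units; beyond the scatter), with hydroxy in place of acetamido on a saturated chain carbon bound to an aromatic carbon. Going by the values given here, that step shows that a change in this substituent can move the number by a modest amount, but no measured compound carries methoxycarbonyl, so neither its size nor its direction transfers directly. A slight rise is expected, with no clear shift beyond the scatter, and the uncertainty is wide enough to include a step of that modest size either way. The expected step is a 1.4-fold higher number from compound 2 to compound 4 (0.15 log units; within the scatter). The value of compound 4 is estimated at 45000 nM, with an expected range from 15000 nM to 130000 nM.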

Compound 4, half-maximal cytotoxic concentration: 33700 nM
Compound 4: the middle estimate sits 1.3-fold (0.13 log units) above what was measured; low and high end bracket the measured number.
By their numbers in this assay, from the lowest: compounds 3, 2 and 4 (each within the scatter of the next); then compound 1.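

In this assay the step of a 1.1-fold higher number from compound 2 to compound 4 (0.03 log units; within the scatter) lies within the scatter, so on this aromatic carbon, para to a fused ring in the words of the structure comparison, hydroxymethyl and methoxycarbonyl cannot be told apart, although the entering group has a double bond outside aromatic rings and no hydrogen-bond donor. The step of a 5.3-fold lower number from compound 1 to compound 4 (0.72 log units; beyond the scatter) lies beyond the scatter and is of about the same size as a 5.6-fold lower number from compound 1 to compound 2 (0.75 log units; beyond the scatter) in the same direction, so among the three groups seen at this place only the acetamidomethyl of compound 1 stands apart from the other two. Nothing available here explains why these groups read as they do.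

As far as these compounds go, it remains open whether a carboxylic acid, a primary amide or a longer ester such as ethoxycarbonyl on this carbon would read with compound 2 and compound 4 or with compound 1. From the compounds shown here alone, it is also open whether the higher number of compound 1 needs the whole acetamidomethyl group, which an acetamido group set directly on the aromatic carbon or a longer acylaminomethyl chain could help to test.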